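A few compounds are considered here, and "the series" means these few. Any claim that something is new, unique, unknown or untested is made for them only; others in the source may bear on it.

Measured in a functional assay on MT4 cells (Homo sapiens) for cytotoxicity; on this read-out higher numbers stand for weaker inhibition and lower numbers for stronger inhibition:
- compound 1 `Cc1cccc(S(=O)(=O)c2cccc(N)c2C#N)c1`: 179000 nM
- compound 2 `N#Cc1c(N)cccc1S(=O)(=O)c1cccc(F)c1`: > 200000 nM

Compound 2 stands at > 200000 nM, which is a limit of this assay and not a number. Compound 3 `N#Cc1cccc(S(=O)(=O)c2cccc(N)c2C#N)c1` has cyano in place of fluoro on an aromatic carbon. Within the data shown here, the one measured step at this place, with fluoro in place of methyl, is an at least 1.1-fold higher number from compound 1 to compound 2 (0.04 log units; that floor lies within the scatter). On that step, no change beyond the scatter is expected in this assay, and the expected size is an at least 1.0-fold lower number from compound 2 to compound 3 (0.02 log units; that floor lies within the scatter). Compound 3 is estimated at 190000 nM, with an expected range of 100000 nM to 250000 nM.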

Compound 3, half-maximal inhibitory concentration: > 200000 nM
Compound 3 ended at the assay's limit; the forecaster's own chance of this, stated with the estimate: 55%; at least 1.0-fold (0.02 log units) between middle value and limit.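

In this assay compound 3 gives > 200000 nM, which is a limit of the assay and not a number. Cyano in place of methyl on this aromatic carbon gives an at least 1.1-fold higher number from compound 1 to compound 3 (0.04 log units; that floor lies within the scatter), so a second replacement of methyl also has a floor that stays within the scatter, as with fluoro. The step from fluoro to cyano cannot be read, because both compounds end at the same limit: the limit of > 200000 nM in this assay, at which 2 of the 3 values shown sit.

Still open, from the compounds shown here alone, is whether an amine or a carboxylic acid on this aromatic carbon would give a value clear of the limit in this assay.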